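The compounds below may be only part of what the source reports. "The series", "measured", "known", "first", "only" and "open" are said of these compounds alone.

Compound 3 `C#CCSc1nc(Nc2cccc(Cl)c2)c2ccncc2n1` gives 56500 nM in a functional assay on PC-3 cells (Homo sapiens) for inhibition, read by MTT assay, with a stated time of 72 h (on this read-out higher numbers stand for weaker inhibition and lower numbers for stronger inhibition), the highest of the two numbers shown. The nearest value belongs to compound 2 `C#CCSc1nc(Nc2ccc(Cl)cc2)c2ccncc2n1`, which gives 19000 nM in this assay; the step between them reads a 3.0-fold higher number from compound 2 to compound 3 (0.47 log units; beyond the scatter). Compound 1 `C#CCSc1nc(Nc2ccccc2)c2ccncc2n1` gives > 80000 nM in this assay, and that is a limit of the assay rather than a number. The two steps that start from it read an at least 4.2-fold lower number from compound 1 to compound 2 (0.62 log units; beyond the scatter) and an at least 1.4-fold lower number from compound 1 to compound 3 (0.15 log units; that floor lies within the scatter). Compound 4 `C#CCSc1nc(Nc2cccc(O)c2)c2ccncc2n1` differs from compound 3 by hydroxy in place of chloro on an aromatic carbon. Among the compounds with values here, none of the measured steps exchanges chloro for hydroxy: they set chloro against hydrogen or compare the two chlorophenyl groups, so they bear on the present step only by showing that the series as a whole sits near the upper end of this assay and that the 3-chlorophenyl compound is the weaker of the two chloro compounds. Compound 4 is therefore expected to show a step of a 1.1-fold higher number from compound 3 to compound 4 (0.03 log units; within the scatter), one that may not rise beyond the scatter. The estimate for compound 4 is 60000 nM, within 20000 nM to 150000 nM.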

Compound 4, half-maximal inhibitory concentration: > 80000 nM
Compound 4: only a limit was reported; the forecaster's own chance of this, stated with the estimate: 40%; at least 1.3-fold (0.12 log units) between middle value and limit.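

In this assay, replacing chloro with hydroxy on this aromatic carbon, meta to a large group, gives a step that reads an at least 1.4-fold higher number from compound 3 to compound 4 (0.15 log units; that floor lies within the scatter), so hydroxy shows no gain over chloro here, though the size of the change cannot be fixed. The comparison with the 4-chlorophenyl compound is clearer, at an at least 4.2-fold higher number from compound 2 to compound 4 (0.62 log units; beyond the scatter), and compound 2 now stands apart from all three other compounds shown. Compound 4, like compound 1, gives only a limit of the assay, and the step between these two cannot be read: the limit of > 80000 nM in this assay, at which 2 of the 4 values shown sit.

On these data alone, how far compound 4 lies beyond its limit remains unknown, so hydroxy and hydrogen cannot be ordered at this position. Also open, as far as these compounds go, is how an amine or a methoxy group on the same carbon would read in this assay.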